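This account rests on a few compounds, and the source may have more. Where it says the series, first, only, none or still open, it means among the compounds named here.

The three measured compounds share one core and differ only in the group on the carbonyl carbon of the anilide. Compound 1 `CN(C)CCC(=O)Nc1cccc(-c2nc3ccccc3s2)c1` gives 21000 nM in an ADME assay on HepG2 cells (Homo sapiens) for inhibition, with a stated time of 72 h; on this read-out higher numbers stand for an effect only at larger amounts of compound and lower numbers for an effect already at smaller amounts. Compound 2 `O=C(CCl)Nc1cccc(-c2nc3ccccc3s2)c1` gives 16000 nM in this assay. For compound 3 `O=C(Nc1cccc(-c2nc3ccccc3s2)c1)c1ccc(Cl)nc1Cl` the assay reports only a limit, > 25000 nM, and not a number. That floor is described by the limit of > 25000 nM in this assay, at which 1 of the 3 values shown sits. Within the data shown here, the steps of an at least 1.1-fold higher number from compound 1 to compound 3 (0.07 log units; that floor lies within the scatter) and an at least 1.5-fold higher number from compound 2 to compound 3 (0.19 log units; that floor lies within the scatter) both end at that limit, and the step of a 1.3-fold lower number from compound 1 to compound 2 (0.12 log units; within the scatter) between the two amides with a saturated chain is likewise small, so none of the measured changes on the carbonyl carbon moved the read-out beyond the scatter.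

Compound 4 `O=C(Nc1cccc(-c2nc3ccccc3s2)c1)c1ccncc1Cl` carries 3-chloropyridin-4-yl in place of 2,6-dichloropyridin-3-yl on a carbonyl carbon. Among the measured compounds shown here, no measured step exchanges one chloropyridinyl group for another, so the nearest guides are the two steps into compound 3, both within the scatter, together with the weak numbers of compound 1 and compound 2. No step beyond the scatter is therefore expected in this assay. For compound 4 the estimated step is a number no higher from compound 3 to compound 4 (the limit leaves the size open). Compound 4 is expected to give about 25000 nM, within a range from 12000 nM to 60000 nM, with a real chance that the assay again reports only a limit.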

Compound 4, half-maximal effective concentration: > 25000 nM
Compound 4 was reported as a limit; the forecaster's own chance of this, stated with the estimate: 60%; the middle value sits exactly at the limit.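

Compound 4 again gives a limit and not a number, so in this assay this outcome at the carbonyl carbon is no longer confined to 2,6-dichloropyridin-3-yl but also holds for 3-chloropyridin-4-yl, which has one chlorine fewer: the limit of > 25000 nM in this assay, at which 2 of the 4 values shown sit. Since compound 3 and compound 4 both stand at this limit, the step between them cannot be read, and the exchange of one chloropyridinyl group for the other has no measurable size here. The two steps that can be read are an at least 1.5-fold higher number from compound 2 to compound 4 (0.19 log units; that floor lies within the scatter) and an at least 1.1-fold higher number from compound 1 to compound 4 (0.07 log units; that floor lies within the scatter), so this second chloropyridinyl group, like the first, is not shown to carry the read-out beyond the scatter from the two amides with a saturated chain.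

From the compounds shown here alone, what compound 3 and compound 4 would give as actual numbers stays open, and with it any difference between their two groups. Also open, going by these compounds, is whether an unsubstituted pyridinyl ring, a carboxylic acid or a longer amine chain on this carbonyl carbon would produce a step beyond the scatter in this assay.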